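A few compounds are considered here, and "the series" means these few. Any claim that something is new, unique, unknown or untested is made for them only; others in the source may bear on it.

Measured compounds:
- compound 1, `Cc1cc(Nc2cc(N3CCN(C)CC3)nc(Nc3cccc(Cl)c3)n2)n[nH]1`, gives 723 nM in a functional assay on A549 cells (Homo sapiens) for antiproliferative activity, read by CCK-8 assay, with a stated time of 72 h; a lower number here means a stronger inhibitor, a higher number a weaker inhibitor
- compound 2, `Cc1cc(Nc2cc(N3CCN(C)CC3)nc(Nc3cccc([N+](=O)[O-])c3)n2)n[nH]1`, gives 926 nM
- compound 3, `Cc1cc(Nc2cc(N3CCN(C)CC3)nc(Nc3ccc(C#N)cc3)n2)n[nH]1`, gives 785 nM

All three share one core and differ only in the ring carried on a nitrogen on an aromatic ring. In this assay the number for compound 1 sits alongside the other two: a 1.3-fold higher number from compound 1 to compound 2 (0.11 log units; within the scatter) and a 1.1-fold higher number from compound 1 to compound 3 (0.04 log units; within the scatter), and between the other two a 1.2-fold lower number from compound 2 to compound 3 (0.07 log units; within the scatter). None of these steps reaches beyond the scatter, so the three compounds cannot be told apart on these numbers.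

Compound 4, `COc1ccc(Nc2nc(Nc3cc(C)[nH]n3)cc(N3CCN(C)CC3)n2)cc1`, is not yet measured. It differs from compound 1 in one place: 4-methoxyphenyl in place of 3-chlorophenyl on a nitrogen on an aromatic ring. For the measured compounds named here, the steps that bear on this change are those already seen at the same position, where a chloro, a nitro and a nitrile group gave numbers that all lie within the scatter of one another. Nothing in these three compounds shows this position moving the number, so the expectation for compound 4 is no step beyond the scatter, in either direction: a 1.1-fold higher number from compound 1 to compound 4 (0.04 log units; within the scatter). The estimate for compound 4 in this assay is therefore 800 nM, expected to fall between 400 nM and 1600 nM.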

Compound 4, half-maximal inhibitory concentration: 2650 nM
Compound 4: middle estimate off by 3.3-fold (0.52 log units), on the low side; the whole stated range lies below it.
By their numbers in this assay, from the lowest: compounds 1, 3 and 2 (each within the scatter of the next); then compound 4.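

In this assay, this position proves not to be indifferent to the ring it carries: with 4-methoxyphenyl in place of 3-chlorophenyl there is a 3.7-fold higher number from compound 1 to compound 4 (0.56 log units; beyond the scatter), and the other two comparisons point the same way, with a 3.4-fold higher number from compound 3 to compound 4 (0.53 log units; beyond the scatter) and a 2.9-fold higher number from compound 2 to compound 4 (0.46 log units; beyond the scatter). All three steps lie beyond the scatter, so the earlier agreement among the chloro, nitro and nitrile compounds did not extend to every group here, and compound 4 is the weakest of the four; the comparison with compound 3, where 4-cyanophenyl gives way to 4-methoxyphenyl, also shows a step with the group's numbered place on the ring unchanged. No measurement shown here bears on the reason for these steps.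

From the compounds shown here alone, whether 3-methoxyphenyl would give a number like that of 4-methoxyphenyl or one like those of the first three compounds remains open. Going by these compounds, it is also open whether the shift belongs to methoxy alone or would also appear with a hydroxyl, an amine or a longer ether chain on the same ring.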